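From methoxy to hydroxymethyl: compound 2 to compound 3

The compounds below may be only part of what the source reports. "The series", "measured", "known", "first", "only" and "open" are said of these compounds alone.

Of the compounds shown here, two on one core have been measured so far. Compound 1 (`O=C(O)C(=O)Nc1nc(-c2cc(Cl)no2)cs1`) reads > 30 mg/kg in a functional assay on the whole organism with Rattus norvegicus as the target (on this read-out higher numbers stand for an effect only at larger amounts of compound and lower numbers for an effect already at smaller amounts), and that value is a limit of the assay, not a number. Among the measured compounds shown here, compound 2 (`COc1cc(-c2csc(NC(=O)C(=O)O)n2)on1`) gives 1.2 mg/kg in this assay and this is the only actual number.

Compound 3 (`O=C(O)C(=O)Nc1nc(-c2cc(CO)no2)cs1`) carries hydroxymethyl in place of methoxy on an aromatic carbon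

For the measured compounds named here, one measured step bears on this carbon, the change from chloro to methoxy, which gave an at least 25-fold lower number from compound 1 to compound 2 (1.39 log units; beyond the scatter) and is large. On these data alone, one end of that step is not a number, given the limit of > 30 mg/kg in this assay, at which 1 of the 2 values shown sits, and its true size stays open. It shows that this carbon can matter a great deal, but it does not test hydroxymethyl directly.

Going by the values given here, compound 2 at 1.2 mg/kg is the only reference for a change away from methoxy, and the expectation is a moderate move towards a higher number, with a wide margin. The expected change is a 2.9-fold higher number from compound 2 to compound 3 (0.46 log units; beyond the scatter) in this assay as a working estimate. For compound 3 the estimated value is 3.5 mg/kg with an expected range from 0.6 mg/kg to 20 mg/kg in this assay for now.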

Compound 3, dose for half-maximal effect: 0.007 mg/kg
Compound 3: middle estimate off by 500-fold (2.70 log units), on the high side, and the stated range ends above it.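

In this assay, this carbon of the ring, next to the ring nitrogen, responds strongly to how the same atoms are joined: a 170-fold lower number from compound 2 to compound 3 (2.23 log units; beyond the scatter), although methoxy and hydroxymethyl have the same heavy-atom count and differ in the counted features only by the hydrogen-bond donor that hydroxymethyl carries. The earlier chloro to methoxy step left open whether methoxy was near the best this carbon could give, and this result shows that it was not, with an at least 4200-fold lower number from compound 1 to compound 3 (3.63 log units; beyond the scatter) now spanning the three groups shown at this place. Compound 1 stands at a limit of the assay, not at a number, so the full span keeps an open end: the limit of > 30 mg/kg in this assay, at which 1 of the 3 values shown sits.

On these data alone, what remains open is whether the hydroxyl hydrogen itself carries the step, which aminomethyl, a carboxylic acid or the longer 2-hydroxyethyl chain on this carbon would help to separate. A dose read out in the whole animal also cannot tell on its own how much of the step arises at the target and how much from the compound's fate in the animal.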